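The compounds below may be only part of what the source reports. "The series", "measured", "known", "first", "only" and "open" are said of these compounds alone.

Compound 1 `CC/C(=C(/c1ccc(/C=C/C(=O)O)cc1)c1ccc2nccn2c1)c1ccccc1` gives 170 nM in a functional assay on MCF7 cells (Homo sapiens) for antiproliferative activity, read by CellTiter-Glo, with a stated time of 5 days (a lower number here means a stronger inhibitor, a higher number a weaker inhibitor), the higher of the two numbers shown. Compound 2 `CC/C(=C(/c1ccc(/C=C/C(=O)O)cc1)c1ccc2scnc2c1)c1ccccc1` gives 90 nM in this assay, and the step of a 1.9-fold lower number from compound 1 to compound 2 (0.28 log units; within the scatter) lies within the scatter. Compound 3 `CC/C(=C(/c1ccc(/C=C/C(=O)O)cc1)c1ccc2ocnc2c1)c1ccccc1` gives > 500 nM in this assay, which is a limit of the assay and not a number (the limit of > 500 nM in this assay, at which 1 of the 3 values shown sits). The steps of an at least 2.9-fold higher number from compound 1 to compound 3 (0.46 log units; beyond the scatter) and an at least 5.5-fold higher number from compound 2 to compound 3 (0.74 log units; beyond the scatter) both run toward weaker inhibition. Compound 4 `CC/C(=C(/c1ccc(/C=C/C(=O)O)cc1)c1ccc2sc(C)nc2c1)c1ccccc1` has not yet been measured in this assay; it differs from compound 1 by a group of 10 heavy atoms (8 carbon, 1 nitrogen, 1 sulfur; one five-membered aromatic ring with 2 hetero atoms, one six-membered aromatic ring of carbon only) in place of a group of 9 heavy atoms (7 carbon, 2 nitrogen; one five-membered aromatic ring with 2 hetero atoms, one six-membered aromatic ring with 1 hetero atom), on a double-bonded chain carbon bound to an aromatic carbon and a double-bonded chain carbon. The step from compound 1 to compound 2 is the one that bears on this change. Going by these compounds, compound 4 carries 2-methyl-1,3-benzothiazol-5-yl, and the effect of that methyl is untested here. Compound 4 is therefore expected to show a step of a 1.9-fold lower number from compound 1 to compound 4 (0.28 log units; within the scatter) that stays within the scatter, much like the step of a 1.9-fold lower number from compound 1 to compound 2 (0.28 log units; within the scatter). The estimate for compound 4 in this assay is 90 nM, between 35 nM and 250 nM.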

Compound 4, half-maximal inhibitory concentration: > 500 nM
Compound 4: only a limit was reported; the forecaster's own chance of this, stated with the estimate: 5%; at least 5.5-fold (0.74 log units) between middle value and limit.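

In this assay, the new result shows that the aromatic carbon of the 1,3-benzothiazol-5-yl group does not accept substitution freely: methyl in place of hydrogen gives an at least 5.5-fold higher number from compound 2 to compound 4 (0.74 log units; beyond the scatter). For the compounds shown here, the earlier compounds showed only that this ring group, without the methyl, stays within the scatter of the group in compound 1, whereas 2-methyl-1,3-benzothiazol-5-yl gives an at least 2.9-fold higher number from compound 1 to compound 4 (0.46 log units; beyond the scatter). The result for compound 4 is a limit of the assay and not a number, and compound 3 also stands at a limit, so the step between these two compounds cannot be read: the limit of > 500 nM in this assay, at which 2 of the 4 values shown sit.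

Going by these compounds, how much weaker than the limit compound 4 and compound 3 are remains open. Also open, on these data alone, is whether the drop belongs to methyl alone or would also appear with an amine or a chlorine on that aromatic carbon.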